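The source may report more compounds than this note shows. Statements on the series, on what has been measured and on what is new or still open speak of the compounds shown alone.

In a functional assay on the whole organism with Mus musculus as the target (on this read-out higher numbers stand for an effect only at larger amounts of compound and lower numbers for an effect already at smaller amounts), the series holds one measured number and two limits. Compound 1 (`CN1C(=O)CCC1(O)c1cccc(C(F)(F)F)c1`) gives 51.6 mg/kg as a measured number. Compound 2 (`CN(C)C(=O)CCC(=O)c1cccc(C(F)(F)F)c1`) gives > 37.5 mg/kg as a limit. Compound 3 (`CC(C)NC(=O)CCC(=O)c1cccc(C(F)(F)F)c1`) gives > 150 mg/kg as a limit, so its standing in this assay is known only in that form.

Compound 4 (`CCC(C)NC(=O)CCC(=O)c1cccc(C(F)(F)F)c1`) departs from compound 3 by a single change (methyl in place of hydrogen on a saturated chain carbon, two bonds along the chain from an amide-type nitrogen): methyl in place of hydrogen on a saturated chain carbon, two bonds along the chain from an amide-type nitrogen. One bond further out, the same change reads isopropyl to sec-butyl.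

Going by the values given here, the one measured step that bears on it is a step that the two limits leave unreadable from compound 2 to compound 3 and no more than that, so no size can be carried over from it. Among the compounds with values here, no measured pair shows what a methyl does at this place. The expectation in this assay is therefore no step beyond the scatter, and no direction can be named. The expected change is a number no higher from compound 3 to compound 4 (the limit leaves the size open) on this estimate. A report of only a limit is about as likely as a number. For compound 4 the estimated dose is 150 mg/kg with an expected range of 70 mg/kg to 320 mg/kg in this assay as it stands.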

Compound 4, dose for half-maximal effect: > 200 mg/kg
Compound 4 was reported as a limit; the forecaster's own chance of this, stated with the estimate: 55%; middle value at least 1.3-fold (0.12 log units) away from the limit.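

Going by these compounds alone, no step among compound 2, compound 3 and compound 4 can be read in this assay, as all three stand only as limits. On these data alone, the size and direction of any effect of methyl in place of hydrogen on a saturated chain carbon, two bonds along the chain from an amide-type nitrogen, remain open.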